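This account rests on a few compounds, and the source may have more. Where it says the series, first, only, none or still open, it means among the compounds named here.

Measured compounds:
compound 1, `Cc1ccc(NC(=O)Nc2ccc(Oc3cc(NCc4ccccc4)ncn3)cc2)cc1C(F)(F)F` — in a functional assay on BaF3 cells (Mus musculus) for inhibition, read by CCK-8 assay, with a stated time of 72 h (on this read-out higher numbers stand for weaker inhibition of growth and lower numbers for stronger inhibition of growth), compound 1 gives 3010 nM
compound 2, `CNc1cc(Oc2ccc(NC(=O)Nc3ccc(C)c(C(F)(F)F)c3)cc2)ncn1` — in this assay compound 2 gives > 10000 nM, a limit of the assay rather than a number
compound 3, `CC(=O)Nc1cc(Oc2ccc(NC(=O)Nc3ccc(CN4CCN(C)CC4)c(C(F)(F)F)c3)cc2)ncn1` — in this assay compound 3 gives 50 nM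

Compound 2 stands at the weak end of the three: its value is only a limit (the limit of > 10000 nM in this assay, at which 1 of the 3 values shown sits), so its true number is not known. Compound 1 and compound 3 differ from it in more than one place, and compound 3 differs from both in several places, so their values are simply recorded as they stand.

The unmeasured compound 4, `Cc1ccc(NC(=O)Nc2ccc(Oc3cc(N4CCNC[C@@H]4C)ncn3)cc2)cc1C(F)(F)F`, differs from compound 2 in one place: 2-methylpiperazin-1-yl in place of methylamino on an aromatic carbon. For the measured compounds named here, the only measured step that bears on the same position is an at least 3.3-fold higher number from compound 1 to compound 2 (0.52 log units; beyond the scatter), where benzylamino in place of methylamino gave the lower number. The 2-methylpiperazin-1-yl group is, like benzylamino, larger than methylamino, so the step from compound 2 to compound 4 is expected to move in the same direction, back toward a measurable number, though how far is uncertain. Compound 4 is therefore estimated at 3000 nM in this assay, with a range from 500 nM to 20000 nM. This estimate corresponds to an expected step of an at least 3.3-fold lower number from compound 2 to compound 4 (0.52 log units; beyond the scatter).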

Compound 4, concentration for 50% growth inhibition: 8120 nM
Beside the measured number, compound 4's estimate is 2.7-fold (0.43 log units) below it; low and high end bracket the measured number.
By their numbers in this assay, from the lowest: compound 3; then compound 1; then compound 4. At a limit, above all of these: compound 2.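

In this assay, 2-methylpiperazin-1-yl in place of benzylamino on this aromatic carbon gives a 2.7-fold higher number from compound 1 to compound 4 (0.43 log units; beyond the scatter), so the gain seen with benzylamino does not follow from simply having more heavy atoms here than methylamino. In place of methylamino, the same group gives an at least 1.2-fold lower number from compound 2 to compound 4 (0.09 log units; that floor lies within the scatter), and that floor lies within the scatter, so no gain over methylamino can be claimed. The true size of this step cannot be read because compound 2 is held only by a limit: the limit of > 10000 nM in this assay, at which 1 of the 4 values shown sits.

Compound 3 gives 50 nM but differs from the others in several places, so its value cannot be assigned to this position. Going by these compounds, whether phenethylamino or morpholin-4-yl on this carbon would come closer to benzylamino, and what the opposite configuration of the methyl-bearing stereocentre would do, remains open.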